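Swapping the Aryl Group on the Saturated Ring Carbon

A few compounds are considered here, and "the series" means these few. Any claim that something is new, unique, unknown or untested is made for them only; others in the source may bear on it.

Within the data shown here, compound 2 `Cc1cc(O)c(C2=NN(c3ccc(S(N)(=O)=O)cc3)C(/C=C/c3ccccc3)C2)cc1Cl` is one of two compounds measured so far in a functional assay on U-251 cells (Homo sapiens) for antiproliferative activity, with a stated time of 48 h (a lower number here means that less compound is tolerated, a higher number that more compound is tolerated), where compound 2 gives 39500 nM. Among the measured compounds shown here, this is the higher of the two numbers, but its only neighbour, compound 1 `Cc1cc(O)c(C2=NN(c3ccc(S(N)(=O)=O)cc3)C(c3ccccc3Cl)C2)cc1Cl`, gives 36900 nM in this assay, and the step of a 1.1-fold higher number from compound 1 to compound 2 (0.03 log units; within the scatter) lies within the scatter, so the two cannot be told apart. Compound 3 `COc1ccc(C2CC(c3cc(Cl)c(C)cc3O)=NN2c2ccc(S(N)(=O)=O)cc2)cc1OC` has not yet been measured. It differs from compound 2 in one place: 3,4-dimethoxyphenyl in place of 2-phenylethenyl on a saturated ring carbon. For the measured compounds named here, the only measured step that bears on this change is the exchange of groups at the same saturated ring carbon, a 1.1-fold higher number from compound 1 to compound 2 (0.03 log units; within the scatter), which stayed within the scatter. On that basis no step beyond the scatter is expected in this assay for compound 3, whose estimated value is 38000 nM, with a range from 15000 nM to 95000 nM. The expected step, a 1.0-fold lower number from compound 2 to compound 3 (0.02 log units; within the scatter), is thus estimated to be negligible.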

Compound 3, concentration lethal to 50% of the cells: 48200 nM
For compound 3 the middle estimate is 1.3-fold (0.10 log units) below the measured one; the measured number falls inside the stated range.
By their numbers in this assay, from the lowest: compounds 1, 2 and 3 (each within the scatter of the next).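

In this assay, 3,4-dimethoxyphenyl on this saturated ring carbon gives a 1.2-fold higher number from compound 2 to compound 3 (0.09 log units; within the scatter) and a 1.3-fold higher number from compound 1 to compound 3 (0.12 log units; within the scatter), so neither step can be told apart from the usual variation between repeats. The exchange for 2-phenylethenyl therefore brings in two oxygen atoms and two hydrogen-bond acceptors without a step beyond the scatter, which the earlier pair, lacking any such oxygen-bearing group, could not show. No measurement offered here explains why these groups give such similar numbers.

All three groups at this position contain a six-membered aromatic ring of carbon only, so the compounds shown leave open what a carboxylic acid, an amine or a short alkyl chain would do there. They also leave open whether any change to the 4-sulfamoylphenyl group would move the number beyond the scatter.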